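Exposure in the trifluoromethyl-for-fluoro step on the shared core

This account rests on a few compounds, and the source may have more. Where it says the series, first, only, none or still open, it means among the compounds named here.

Measured so far:
compound 1 `COC(=O)N[C@H](C(=O)N1CCC[C@H]1C(=O)Nc1ccc([C@H]2CC[C@H](c3ccc(NC(=O)[C@@H]4CCCN4C(=O)[C@@H](NC(=O)OC)C(C)C)cc3)N2c2ccc(C(F)(F)F)cc2)cc1)C(C)C` gives 1360 ng.h/mL in an ADME assay on the whole organism (plasma) for pharmacokinetics, with Rattus norvegicus as the target, at a dose of 3 mg/kg by the oral route; a higher number here means more compound in the circulation at the dose given, a lower number less compound in the circulation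
compound 2 `COC(=O)N[C@H](C(=O)N1CCC[C@H]1C(=O)Nc1ccc([C@@H]2CC[C@@H](c3ccc(NC(=O)[C@@H]4CCCN4C(=O)[C@@H](NC(=O)OC)C(C)C)cc3)N2c2ccc(F)cc2)cc1)C(C)C` gives 750 ng.h/mL
compound 3 `COC(=O)N[C@H](C(=O)N1CCC[C@H]1C(=O)Nc1ccc([C@H]2CC[C@H](c3ccc(NC(=O)[C@@H]4CCCN4C(=O)[C@@H](NC(=O)OC)C(C)C)cc3)N2c2ccc(F)cc2)cc1)C(C)C` gives 6360 ng.h/mL

Compound 2 stands lowest of the three numbers in this assay; its gap to compound 1 is within the scatter, its gap to compound 3 is not. Compound 4 `COC(=O)N[C@H](C(=O)N1CCC[C@H]1C(=O)Nc1ccc([C@@H]2CC[C@@H](c3ccc(NC(=O)[C@@H]4CCCN4C(=O)[C@@H](NC(=O)OC)C(C)C)cc3)N2c2ccc(C(F)(F)F)cc2)cc1)C(C)C` differs from compound 2 by trifluoromethyl in place of fluoro on an aromatic carbon. Among the measured compounds shown here, two measured steps bear on this: a 4.7-fold higher number from compound 1 to compound 3 (0.67 log units; beyond the scatter), the reverse of the present change at the other configuration, and an 8.5-fold higher number from compound 2 to compound 3 (0.93 log units; beyond the scatter), which (the fact that compounds 2 and 3 differ only in the configuration as drawn). Both point the same way, so a modest downward step is expected for compound 4, a 3.8-fold lower number from compound 2 to compound 4 (0.57 log units; beyond the scatter). Compound 4 is therefore estimated at 200 ng.h/mL, in the range 50 ng.h/mL to 800 ng.h/mL.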

Compound 4, area under the concentration-time curve: 500 ng.h/mL
Compound 4: the middle estimate sits 2.5-fold (0.40 log units) below what was measured, and the stated range covers the measured number.
By their numbers in this assay, from the lowest: compounds 4, 2 and 1 (each within the scatter of the next, the first and the last beyond it); then compound 3.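

At this configuration, the change from 4-fluorophenyl to 4-(trifluoromethyl)phenyl in this assay gives no step beyond the scatter (a 1.5-fold lower number from compound 2 to compound 4 (0.18 log units; within the scatter)), so its size depends on the configuration of the shared core: the same change on two cores in this assay, a 4.7-fold higher number (0.67 log units; beyond the scatter) from compound 1 to compound 3 and a 1.5-fold higher number (0.18 log units; within the scatter) from compound 4 to compound 2, 3.1-fold (0.49 log units) apart, beyond the scatter of two such steps. The drawn configuration still moves the number with trifluoromethyl in place (a 2.7-fold lower number from compound 1 to compound 4 (0.43 log units; beyond the scatter)): the fact that compounds 1 and 4 differ only in the configuration as drawn.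

Only fluoro and trifluoromethyl are shown at this position, so it remains open whether a nitrile or a methoxy group would show the same dependence on configuration. The compounds shown also do not separate how much of each difference comes from uptake and how much from removal from the circulation.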